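The compounds below may be only part of what the source reports. "The series", "measured", "known", "first", "only" and "open" are said of these compounds alone.

Series notes. Two compounds carry a measurement. Compound 1 `COc1ccc(-c2cc3[nH]nc(-c4cc(OC)c(OC)c(OC)c4)n3n2)cc1` gives 26800 nM in a functional assay on SGC-7901 cells (Homo sapiens) for antiproliferative activity, read by MTT assay, with a stated time of 72 h; on this read-out higher numbers stand for weaker inhibition and lower numbers for stronger inhibition. Compound 2 `COc1ccc(-c2nnc3sc(-c4ccc(C)cc4)nn23)c(OC)c1OC` gives 186 nM in this assay and stands lowest of the two numbers shown; its nearest neighbour is compound 1, whose number is higher by a gap beyond the usual scatter. The two values show no more than that, since the two structures differ in several places at once.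

Compound 3 `COc1ccc(-c2nn3c(-c4ccc(OC)c(OC)c4OC)nnc3s2)cc1N` has not yet been measured. It differs from compound 2 in one place: 3-amino-4-methoxyphenyl in place of 4-methylphenyl on an aromatic carbon. Among the measured compounds shown here, no step between measured compounds that differ in a single place is available to anchor the change, so the size of the step rests on judgement alone. For compound 3 a step of a 1.6-fold lower number from compound 2 to compound 3 (0.19 log units; within the scatter) is expected, leaning towards a somewhat lower number but not clearly beyond the scatter. The estimate for compound 3 in this assay is 120 nM, with a range from 30 nM to 500 nM.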

Compound 3, half-maximal inhibitory concentration: 62 nM
Compound 3: middle estimate off by 1.9-fold (0.29 log units), on the high side; low and high end bracket the measured number.
By their numbers in this assay, from the lowest: compound 3; then compound 2; then compound 1.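

In this assay, among the compounds shown here, the first single-place step is a 3.0-fold lower number from compound 2 to compound 3 (0.48 log units; beyond the scatter), on replacing 4-methylphenyl with 3-amino-4-methoxyphenyl on the aromatic carbon next to the ring nitrogen and next to the ring sulfur. This position therefore accepts the substituted phenyl ring, with its added amine and methoxy group, without loss of inhibition, and the modest step lies beyond the scatter. No independent data bear on the reason for this step.

The compounds shown do not separate the amine from the methoxy group, so 3-aminophenyl and 4-methoxyphenyl at this position remain open questions. Also open, from the compounds shown here alone, is whether a hydroxyl group or a carboxylic acid could take the place of the amine, and whether a step of this size would hold on the core of compound 1.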